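Compound 1 Against Its Hydroxyethyl Counterpart

A few compounds are considered here, and "the series" means these few. Any claim that something is new, unique, unknown or untested is made for them only; others in the source may bear on it.

Measured compounds:
compound 1 `CC(C)[C@H](NC(=O)CN(c1ncnc2c1ncn2C1CCCCO1)C1CC1)C(=O)OCc1ccccc1` — 34.9%
compound 2 `O=C(CN(c1nc(Cl)nc2[nH]cnc12)C1CC1)NCC(=O)OCc1ccccc1` — 41.9%
compound 3 `O=C(CN(c1nc(Cl)nc2[nH]cnc12)C1CC1)N[C@@H](CO)C(=O)O` — 39.8%

Three compounds have been run in a functional assay on the whole organism (Tail, strain ICR) with Mus musculus as the target, in the tail flick test, with a stated time of 60 min, at a dose of 25 umol/kg by the oral route; on this read-out lower numbers stand for a weaker effect and higher numbers for a stronger effect at the one dose given. Compound 1 gives 34.9%, compound 2 gives 41.9%, and compound 3 gives 39.8%. On the numbers alone compound 1 carries the smallest figure, yet the gaps to compound 3, the nearest, and to compound 2, the furthest, both fall within the usual scatter, so the three cannot be separated in this assay.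

Compound 4 `C[C@@H](O)[C@H](NC(=O)CN(c1ncnc2c1ncn2C1CCCCO1)C1CC1)C(=O)OCc1ccccc1` has not yet been measured. It differs from compound 1 in one place: 1-hydroxyethyl in place of isopropyl on a saturated chain carbon bound to an amide-type nitrogen and a carbonyl carbon. For the measured compounds named here, no step between measured compounds bears on this change, so nothing in the data points to a shift in either direction. The step from compound 1 to compound 4 in this assay is therefore expected to be a number 1.1 percentage points higher from compound 1 to compound 4 (within the scatter), none beyond the scatter. Compound 4 is estimated to give 36%, with a range from 22% to 50%.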

Compound 4, a percentage reported as activity, at one dose (the size of the read-out at that dose, not a potency): 28.4%
Estimate against measurement, compound 4: 7.6 percentage points above; measured number inside the range.
By their numbers in this assay, from the lowest: compounds 4, 1, 3 and 2 (each within the scatter of the next, the first and the last beyond it).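

In this assay the position on the saturated chain carbon bound to an amide-type nitrogen and a carbonyl carbon now has its first reading, with a number 6.5 percentage points lower from compound 1 to compound 4 (within the scatter) for 1-hydroxyethyl in place of isopropyl. The exchange keeps the count of heavy atoms, puts an oxygen in place of a carbon and adds a hydrogen-bond donor, yet the step stays within the scatter, so at this one dose the two groups cannot be told apart. Nothing at hand accounts for the reading.

The compounds shown leave open whether a carboxylic acid, an amine or a longer chain at this place would give a step beyond the scatter. As far as these compounds go, whether the exchange reads the same way at other doses or times also remains open.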